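The source may hold more compounds than are shown below. What is called first, only, known or untested is meant among the compounds shown, and "the series" means these compounds.

Compound 1 `O=C(CCc1ccc(C(F)(F)F)cc1)Nc1ccc2nc(N3CCC3)ccc2c1` is tested in a functional assay on HEK293 cells for activation of melanin-concentrating hormone receptor 1 (Rattus norvegicus), read by inositol phosphate accumulation (on this read-out higher numbers stand for an effect only at larger amounts of compound and lower numbers for an effect already at smaller amounts), where compound 1 gives 56 nM. Among the three measured compounds it stands second highest; compound 2 `O=C(CCc1ccc(C(F)(F)F)cc1)Nc1ccc2nc(N3CCC(NS(=O)(=O)O)C3)ccc2c1` gives 50 nM, and the difference a 1.1-fold lower number from compound 1 to compound 2 (0.05 log units; within the scatter) stays within the scatter, while compound 3 `CC1CCCN1c1ccc2cc(NC(=O)CCc3ccc(C(F)(F)F)cc3)ccc2n1` gives 270 nM, a step of a 4.8-fold higher number from compound 1 to compound 3 (0.68 log units; beyond the scatter) beyond it. Compound 4 `CC1CCN(c2ccc3cc(NC(=O)CCc4ccc(C(F)(F)F)cc4)ccc3n2)C1` differs from compound 1 by 3-methylpyrrolidin-1-yl in place of azetidin-1-yl on an aromatic carbon. Within the data shown here, two measured steps bear on this: the five-membered ring with a 3-(sulfoamino) group changed little, a 1.1-fold lower number from compound 1 to compound 2 (0.05 log units; within the scatter), whereas the 2-methylpyrrolidin-1-yl group weakened the effect, a 4.8-fold higher number from compound 1 to compound 3 (0.68 log units; beyond the scatter). A methyl at the 3-position is closer to the first case, so a small step toward a higher number is expected, a 1.8-fold higher number from compound 1 to compound 4 (0.25 log units; within the scatter). Compound 4 is therefore estimated at 100 nM, between 40 nM and 250 nM.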

Compound 4, half-maximal effective concentration: 400 nM
Beside the measured number, compound 4's estimate is 4.0-fold (0.60 log units) below it, outside the stated range (above it).
By their numbers in this assay, from the lowest: compounds 2 and 1 (each within the scatter of the next); then compounds 3 and 4 (each within the scatter of the next).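

Replacing azetidin-1-yl with 3-methylpyrrolidin-1-yl carries a clear cost (a 7.1-fold higher number from compound 1 to compound 4 (0.85 log units; beyond the scatter)), while moving the methyl around the ring gives no difference that can be told apart (a 1.5-fold higher number from compound 3 to compound 4 (0.17 log units; within the scatter)). On the same five-membered ring, methyl in place of sulfoamino also counts (an 8.0-fold higher number from compound 2 to compound 4 (0.90 log units; beyond the scatter)), so the larger ring alone does not set the number and the group it carries matters. Nothing measured here gives a reason for this. Still open, as far as these compounds go, is how unsubstituted pyrrolidin-1-yl would compare, and whether an amine or a carboxylic acid on that ring carbon would match sulfoamino.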